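The source may hold more compounds than are shown below. What is called first, only, known or untested is meant among the compounds shown, and "the series" means these compounds.

In an assay on HEK293 cells for positive allosteric modulation of metabotropic glutamate receptor 5 (Homo sapiens), read by FLIPR, with a stated time of 1 h (a lower number here means that less compound is needed, a higher number that more compound is needed for the effect), compound 1, `O=C1NCCc2nc(C#Cc3cccc(F)c3)sc21`, gives 290 nM. Within the data shown here, compound 2, `Cc1cccc(C#Cc2nc3c(s2)C(=O)NCC3)c1`, differs from compound 1 only by methyl in place of fluoro on an aromatic carbon, and that step, an at least 34-fold higher number from compound 1 to compound 2 (1.53 log units; beyond the scatter), is the single measured step in the set. The value of compound 2, > 10000 nM, is a limit of this assay and not a number. Compound 3, `CCC(=O)N1CCc2nc(C#Cc3ccccc3)sc2C1`, is recorded at > 10000 nM, which is also a limit of this assay rather than a number. Compound 3 therefore stands at the limit of > 10000 nM in this assay, at which 2 of the 3 values shown sit, and nothing narrower is known of where it lies.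

Compound 4, `O=C(C1CCCO1)N1CCc2nc(C#Cc3ccccc3)sc2C1`, arises from compound 3 by oxolan-2-yl in place of ethyl on a carbonyl carbon. Among the measured compounds shown here, the one measured step concerns a substituent on an aromatic carbon and does not touch the carbonyl carbon where this change sits, so no measured step bears on it, and neither direction nor size can be drawn from the data. With compound 3 at a limit, the expected step of a number no higher from compound 3 to compound 4 (the limit leaves the size open) can only be stated against that limit. Compound 4 is thus expected to give about 10000 nM in this assay. The range for compound 4 is estimated to run from 2500 nM to 40000 nM, and a further limit rather than a number is the more likely outcome.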

Compound 4, half-maximal effective concentration: 790 nM
The estimate for compound 4 lay 13-fold (1.10 log units) above the measured number, and the stated range ends above it.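

Among these compounds, at the carbonyl carbon whose other neighbour is the amide-type nitrogen in a ring, putting oxolan-2-yl in place of ethyl gives an at least 12-fold lower number from compound 3 to compound 4 (1.10 log units; beyond the scatter) in this assay, and this is the only measured step at this place. Compound 4 shows that a group on this carbonyl carbon can carry a measurable value in this assay, which compound 3 alone did not show. Compound 3 stands at a limit and not at a number, so the full size of the step stays open: the limit of > 10000 nM in this assay, at which 2 of the 4 values shown sit.

The compounds shown do not separate the role of the ring oxygen of oxolan-2-yl from that of the ring itself or of the larger group, and a cyclopentyl group, an oxan-2-yl group or a longer chain on the same carbonyl carbon would each bear on that question. Also open, from the compounds shown here alone, is whether the change from propanoyl to (oxolan-2-yl)carbonyl would give a step of similar direction and size with a fluoro group on the aromatic ring of compound 4.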